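The compounds below may be only part of what the source reports. "The series", "measured", "known", "first", "only" and "open" are said of these compounds alone.

Compound 1 `CS(=O)(=O)c1cc(C(=O)N=C(N)N)c(F)cc1F` gives 630 nM in a functional assay for inhibition of sodium/hydrogen exchanger (Oryctolagus cuniculus); on this read-out higher numbers stand for weaker inhibition and lower numbers for stronger inhibition.
Compound 2 `Cc1cc(C2CCC2)c(S(C)(=O)=O)cc1C(=O)N=C(N)N` gives 8.2 nM in this assay.

Of the two numbers, compound 2 holds the lower one, and its gap to compound 1 lies beyond the scatter. Compound 3 `Cc1cc(SC(C)C)c(S(C)(=O)=O)cc1C(=O)N=C(N)N` differs from compound 2 in a single place: isopropylsulfanyl in place of cyclobutyl on an aromatic carbon. For the measured compounds named here, no measured pair shows this change, so nothing here tells how large its effect is. The step of a 1.5-fold higher number from compound 2 to compound 3 (0.17 log units; within the scatter) is expected to be small, at most near the edge of the scatter, if anything toward a weaker number. Compound 3 is therefore estimated at 12 nM, within a range from 4 nM to 40 nM.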

Compound 3, half-maximal inhibitory concentration: 12 nM
Compound 3: middle estimate and measured number agree at the digits printed; measured number inside the range.
By their numbers in this assay, from the lowest: compounds 2 and 3 (each within the scatter of the next); then compound 1.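

Replacing cyclobutyl with isopropylsulfanyl gives a 1.5-fold higher number from compound 2 to compound 3 (0.17 log units; within the scatter) in this assay. At this position, ortho to a methylsulfonyl group, an open group containing sulfur and a four-membered carbon ring of equal heavy-atom count therefore cannot be told apart on this read-out, although one has a hydrogen-bond acceptor and the other has none. No supporting data explain this closeness. As far as these compounds go, whether an amine, a carboxylic acid or a longer chain here would keep a number of this order remains open. So does what a bare hydrogen at this position would give.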